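The source may report more compounds than this note shows. Statements on the series, on what has been measured and on what is new or still open speak of the compounds shown alone.

Compound 1 `CCc1ccc(-c2cc(C(=O)Nc3ccc(Oc4ccnc(C(=O)NC)c4)cc3)ncn2)cc1` gives 29300 nM
Compound 2 `CNC(=O)c1cc(Oc2ccc(NC(=O)c3nccc(-c4cccc(Cl)c4)n3)cc2)ccn1` gives 20800 nM
Compound 3 `CCc1ccc(-c2cc(C(=O)Nc3ccc(Oc4ccnc(C(=O)NC)c4)c(F)c3)ncn2)cc1` gives 15600 nM

All three values come from a functional assay on PC-3 cells (Homo sapiens) for cytotoxicity, read by MTT assay, with a stated time of 72 h (on this read-out lower numbers stand for stronger inhibition and higher numbers for weaker inhibition), and lie within the scatter of one another, so compound 3, at 15600 nM, holds no clear place among them. Compound 4 `CNC(=O)c1cc(Oc2ccc(NC(=O)c3cc(-c4ccc(F)cc4)ncn3)cc2F)ccn1` has not yet been measured. It differs from compound 3 by fluoro in place of ethyl on an aromatic carbon, which in words is fluoro in place of ethyl on an aromatic carbon, or 4-ethylphenyl to 4-fluorophenyl.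

Within the data shown here, no measured step shows this change. Among the measured compounds shown here, the one step available is a 1.9-fold lower number from compound 1 to compound 3 (0.27 log units; within the scatter) and it concerns a different change, fluoro in place of hydrogen on an aromatic carbon, a fluoro that compound 4 keeps. The 4-ethylphenyl group and the core of compound 3 are both absent from compound 2, which gives 20800 nM and remains within the scatter of compound 3. Nothing measured therefore points to a step beyond the scatter in this assay in either direction. The expected change is a 1.2-fold higher number from compound 3 to compound 4 (0.06 log units; within the scatter) and no more than that is estimated here. The estimated value for compound 4 is 18000 nM with expected bounds of 7000 nM and 42000 nM in this measurement.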

Compound 4, half-maximal inhibitory concentration: > 100000 nM
Compound 4 was reported as a limit (the forecaster's own chance of this, stated with the estimate: 15%); middle value at least 5.5-fold (0.74 log units) away from the limit.
By their numbers in this assay, from the lowest: compounds 3, 2 and 1 (each within the scatter of the next). At a limit, above all of these: compound 4.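

In this assay, this is the first change shown on this aromatic carbon, para to a large group, and putting fluoro in place of ethyl there gives an at least 6.4-fold higher number from compound 3 to compound 4 (0.80 log units; beyond the scatter). Among these compounds, the position is therefore not indifferent to what it carries: this single exchange moves the read-out beyond the scatter, whereas the only earlier step, the fluoro at another place in a 1.9-fold lower number from compound 1 to compound 3 (0.27 log units; within the scatter), stayed within it. Compound 4 is reported only as a limit and not as a number, so the step has a minimum size but no known full size: the limit of > 100000 nM in this assay, at which 1 of the 4 values shown sits.

With only ethyl and fluoro shown on this carbon in this core, it stays open whether the step follows from the loss of ethyl or from the arrival of fluoro, and what a hydrogen, a propyl chain or an amine would give at the same place. Going by these compounds, it also stays open whether the same exchange would give a step of this kind on the core of compound 1, which lacks the other fluoro.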